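A ring swap on a short-lived compound

A few compounds are considered here, and "the series" means these few. Any claim that something is new, unique, unknown or untested is made for them only; others in the source may bear on it.

Compound 1 `COC(=O)CCNC(=O)[C@@H]1O[P@](=O)(OCOC(=O)c2ccnn2C)OCC1(C)C`: < 0.16 h
Compound 2 `COC(=O)CCNC(=O)[C@@H]1O[P@@](=O)(OCOC(=O)c2ccnn2C)OCC1(C)C`: > 1 h
Compound 3 `COC(=O)CCNC(=O)[C@@H]1O[P@](=O)(Oc2ccc(C#N)cc2)OCC1(C)C`: 0.46 h

In an ADME assay on blood (Homo sapiens) for pharmacokinetics (on this read-out higher numbers stand for a longer-lived compound and lower numbers for a shorter-lived compound), compound 1 gives < 0.16 h, which is a limit of the assay rather than a number. Compound 2 gives > 1 h, also a limit. Compound 3 gives 0.46 h. Compound 1 therefore sits at the short-lived end of the three values shown, at the limit of < 0.16 h in this assay, at which 1 of the 3 values shown sits. Compound 4 `COC(=O)CCNC(=O)[C@@H]1O[P@](=O)(OCOC(=O)c2scnc2C)OCC1(C)C` has not been measured; it differs from compound 1 by 4-methyl-1,3-thiazol-5-yl in place of 1-methyl-1H-pyrazol-5-yl on a carbonyl carbon. Among the measured compounds shown here, the one measured step, an at least 6.2-fold higher number from compound 1 to compound 2 (0.79 log units; beyond the scatter), rests on a difference in configuration alone the fact that compounds 1 and 2 differ only in the configuration as drawn and leaves the acyl ring untouched, so no measured step speaks to the ring swap. Keeping the configuration of compound 1, compound 4 is expected to stay short-lived, a step that the limit leaves unreadable from compound 1 to compound 4. The estimate for compound 4 is 0.15 h, ranging from 0.05 h to 0.5 h.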

Compound 4, half-life: < 0.16 h
Compound 4: only a limit was reported; the forecaster's own chance of this, stated with the estimate: 60%; the middle value is on the limit's open side.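

Among the compounds shown here, compound 1 and compound 4 both stop at the same limit of the assay, so no step between them can be read: the limit of < 0.16 h in this assay, at which 2 of the 4 values shown sit. As far as these compounds go, whether 4-methyl-1,3-thiazol-5-yl in place of 1-methyl-1H-pyrazol-5-yl changes the half-life at all stays open.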